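This account rests on a few compounds, and the source may have more. Where it says the series, first, only, none or still open, it means among the compounds named here.

Compound 1 `COc1ccc(-c2cnc(NC(=O)c3cnc[nH]3)n2C)cc1`: > 100000 nM in a toxicity assay on THP-1 cells (Homo sapiens) for inhibition; on this read-out higher numbers stand for lower toxicity in this test and lower numbers for higher toxicity in this test
Compound 2 `COc1ccc(-c2cn(C)c(NC(=O)c3ccc(F)cc3)n2)cc1`: > 50000 nM.

For compound 1 the value > 100000 nM is a limit of the test, not a number. For compound 2 the value > 50000 nM is likewise a limit. Compound 1 therefore stands at the top of what was recorded (the limit of > 100000 nM in this assay, at which 1 of the 2 values shown sits), and compound 2 also stops at a limit (the limit of > 50000 nM in this assay, at which 1 of the 2 values shown sits). Compound 3 `COc1ccc(-c2cnc(NC(=O)c3ccccc3C#N)n2C)cc1` differs from compound 1 by 2-cyanophenyl in place of 1H-imidazol-5-yl on a carbonyl carbon. For the measured compounds named here, no measured step covers this change, and no step beyond the scatter is expected in this assay. The change from compound 1 to compound 3 is estimated as a number no higher from compound 1 to compound 3 (the limit leaves the size open). Compound 3 is expected to give 100000 nM, between 30000 nM and 300000 nM.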

Compound 3, half-maximal cytotoxic concentration: > 100000 nM
Compound 3 was reported as a limit; the forecaster's own chance of this, stated with the estimate: 80%; the middle value lies on the limit itself.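

No step can be read between compound 1 and compound 3: each stops at a limit of the test. The compounds shown leave open whether 2-cyanophenyl in place of 1H-imidazol-5-yl changes toxicity at all.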